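This account rests on a few compounds, and the source may have more. Where it says the series, first, only, none or still open, it means among the compounds named here.

Compound 1 `COC(=O)/C=C/[C@H]1OCCC[C@@H]1O[Si](C)(C)C(C)(C)C` carries a methoxycarbonyl on its double-bonded chain, and in a functional assay on MCF7S cells (Homo sapiens) (on this read-out lower numbers stand for stronger inhibition of growth and higher numbers for weaker inhibition of growth), compound 1 gives 24000 nM. Compound 2 `CC(C)(C)[Si](C)(C)O[C@H]1CCCO[C@@H]1/C=C/CO` differs by hydroxymethyl in place of methoxycarbonyl on a double-bonded chain carbon bound to a double-bonded chain carbon, and the step is a 2.5-fold higher number from compound 1 to compound 2 (0.41 log units; beyond the scatter). Compound 3 `COC(=O)/C=C\[C@H]1OCCC[C@@H]1O[Si](C)(C)C(C)(C)C` shares every atom and bond with compound 1, the difference being (the two compounds have the same atoms and bonds and differ only in configuration as drawn: 1 of 3 stereo elements differ; a double bond is drawn E in compound 1 and Z in compound 3); in this assay compound 3 gives 32000 nM, and the step is a 1.3-fold higher number from compound 1 to compound 3 (0.12 log units; within the scatter), which fits (the fact that compounds 1 and 3 differ only in the configuration as drawn). Compound 2 gives 61000 nM in this assay, and from compound 2 to compound 3 the step is a 1.9-fold lower number from compound 2 to compound 3 (0.28 log units; within the scatter).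

Compound 4 `CC(C)(C)[Si](C)(C)O[C@H]1CCCO[C@@H]1/C=C\CO` is not yet measured. It differs from compound 3 by hydroxymethyl in place of methoxycarbonyl on a double-bonded chain carbon bound to a double-bonded chain carbon, the same change already seen between compound 1 and compound 2, at the same place. From compound 3 to compound 4 the step expected is a 2.5-fold higher number from compound 3 to compound 4 (0.40 log units; beyond the scatter), resting on the measured step of a 2.5-fold higher number from compound 1 to compound 2 (0.41 log units; beyond the scatter) for the same change. Compound 4 is therefore expected to give about 80000 nM in this assay, with a range estimated from 35000 nM to 180000 nM.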

Compound 4, concentration for 50% growth inhibition: 6400 nM
Estimate against measurement, compound 4: 13-fold (1.10 log units) above; the whole stated range lies above it.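

Replacing methoxycarbonyl with hydroxymethyl on the core of compound 3 gives a 5.0-fold lower number from compound 3 to compound 4 (0.70 log units; beyond the scatter) in this assay, so this change does not carry over from the core with the double bond drawn E to the one with it drawn Z: the same change on two cores in this assay, a 2.5-fold higher number (0.41 log units; beyond the scatter) from compound 1 to compound 2 and a 5.0-fold lower number (0.70 log units; beyond the scatter) from compound 3 to compound 4, 13-fold (1.10 log units) apart, beyond the scatter of two such steps. Among the hydroxymethyl compounds, the double bond alone separates the pair, with a 9.5-fold lower number from compound 2 to compound 4 (0.98 log units; beyond the scatter), and a 3.8-fold lower number from compound 1 to compound 4 (0.57 log units; beyond the scatter) combines the change of group with the change of double bond, so it cannot be assigned to either one: the fact that compounds 2 and 4 differ only in the configuration as drawn. This does not show why the two cores part ways, and with a single pair on each core it gives no rule for any further core.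

The compounds shown leave open whether a carboxylic acid or an amine in place of the hydroxymethyl would follow compound 2 or compound 4. They also leave open whether a longer chain ending in a hydroxyl would keep the difference between the E and Z forms.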